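A Ring Exchange on Compound 3 and Its Expected Outcome

The compounds below may be only part of what the source reports. "The series", "measured", "known", "first", "only" and "open" are said of these compounds alone.

Three compounds sharing one core were measured in an in vitro assay on HEK385-7 cells for displacement of a labelled ligand from prostaglandin D2 receptor 2 (Homo sapiens); a higher number here means a weaker inhibitor, a lower number a stronger inhibitor. Compound 1 `O=C(O)Cc1sc(CSc2ccccc2)nc1-c1ccc(Cl)cc1` gives 250 nM, compound 2 `O=C(O)Cc1sc(Cc2ccccc2-c2ccccc2)nc1-c1ccc(Cl)cc1` gives 41 nM, and compound 3 `O=C(O)Cc1sc(C(c2ccc(F)cc2)c2ccc(F)cc2)nc1-c1ccc(Cl)cc1` gives 9.7 nM. Compound 3 thus holds the lowest number of the three, and its gaps to compound 2 and to compound 1 both lie beyond the scatter, so it is the most potent of the set. Compound 4 `Cc1cc(-c2nc(C(c3ccc(F)cc3)c3ccc(F)cc3)sc2CC(=O)O)cnc1N` has not yet been measured. It differs from compound 3 in one place: 6-amino-5-methylpyridin-3-yl in place of 4-chlorophenyl on an aromatic carbon. Among the measured compounds shown here, no measured pair shows this exchange, so its size is unknown. In this assay the step is expected to stay within the scatter or lean slightly toward a higher number. Compound 4 is therefore estimated at 15 nM, between 4 nM and 60 nM. This expectation means a step of a 1.5-fold higher number from compound 3 to compound 4 (0.19 log units; within the scatter).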

Compound 4, half-maximal inhibitory concentration: 880 nM
Compound 4: middle estimate off by 59-fold (1.77 log units), on the low side; measured number above the stated range.
By their numbers in this assay, from the lowest: compound 3; then compound 2; then compound 1; then compound 4.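

In this assay the place next to the ring nitrogen proves far from tolerant: 6-amino-5-methylpyridin-3-yl in place of 4-chlorophenyl brings a 91-fold higher number from compound 3 to compound 4 (1.96 log units; beyond the scatter) and so costs most of the potency of compound 3. Among the compounds shown here, all the earlier compounds carried 4-chlorophenyl here, so only this step shows that the place matters. Nothing measured here accounts for the size of this step.

The entering group changes the ring nitrogen, the amine and the methyl together, so their shares remain unseparated. Going by these compounds, how a plain phenyl or a 6-aminopyridin-3-yl would behave here stays open.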